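The source may hold more compounds than are shown below. What is called first, only, known or untested is meant among the compounds shown, and "the series" means these compounds.

Compound 1 `Nc1nc(F)cc2c1ncn2[C@@H]1C=C(CCO)[C@@H](O)[C@H]1O`: > 300000 nM
Compound 2 `Nc1ncc(F)c2c1ncn2[C@@H]1C=C(CO)[C@@H](O)[C@H]1O`: > 300000 nM
Compound 3 `Nc1ncc(F)c2c1ncn2[C@@H]1C=C(CCO)[C@@H](O)[C@H]1O`: > 300000 nM

These readings come from an ADME assay on HFF cells (Homo sapiens) for cytotoxicity (on this read-out higher numbers stand for lower toxicity in this test and lower numbers for higher toxicity in this test), and the whole set rests on (the limit of > 300000 nM in this assay, at which 3 of the 3 values shown sit). Compound 2 gives > 300000 nM, which is a limit of the assay and not a number. Compound 4 `Cc1cnc(N)c2ncn([C@@H]3C=C(CO)[C@@H](O)[C@H]3O)c12` differs from compound 2 as follows: methyl in place of fluoro on an aromatic carbon. The change is methyl in place of fluoro on an aromatic carbon. Going by the values given here, the one measured step, a step that the two limits leave unreadable from compound 2 to compound 3, concerns a different change and offers no size to carry over. No readable step is therefore expected in this assay, and compound 4 is expected to stay near the same limit. The expected change is a number no higher from compound 2 to compound 4 (the limit leaves the size open). Compound 4 is estimated at 300000 nM, with an expected range of 100000 nM to 600000 nM.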

Compound 4, half-maximal cytotoxic concentration: 247000 nM
Beside the measured number, compound 4's estimate is 1.2-fold (0.08 log units) above it; the measured number falls inside the stated range.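

In this assay, going by these compounds alone, compound 4 gives 247000 nM, the only reading in the set that is a number. Methyl in place of fluoro on an aromatic carbon, para to an amino group, gives an at least 1.2-fold lower number from compound 2 to compound 4 (0.08 log units; that floor lies within the scatter), so no step beyond the scatter is shown at this position. The reading for compound 2 is a limit and not a number, which leaves the true size of the step open: the limit of > 300000 nM in this assay, at which 3 of the 4 values shown sit.

The compounds shown leave open how an amine or a carboxylic acid on this aromatic carbon would read. They also leave open whether methyl in place of fluoro on compound 3 would give a number.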